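Series notes: a fluoro removed at the limit

This account rests on a few compounds, and the source may have more. Where it says the series, first, only, none or still open, it means among the compounds named here.

Measured so far in a functional assay on KYSE-410 cells (Homo sapiens) for antiproliferative activity, read by MTT assay, with a stated time of 72 h (on this read-out higher numbers stand for weaker inhibition and lower numbers for stronger inhibition), all values being limits:
- Compound 1 (`O=C(Nc1ccc(F)cc1)c1ccnc2cc(Br)ccc12`), limit > 20000 nM
- Compound 2 (`O=C(Nc1ccc(Cl)cc1)c1cc(=O)[nH]c2cc(Br)ccc12`), limit > 20000 nM
- Compound 3 (`O=C(Nc1ccc(F)cc1F)c1cc(=O)[nH]c2cc(Br)ccc12`), limit > 20000 nM

Compound 3 has no numerical value, only a limit, and it stands with the other two compounds at the limit of > 20000 nM in this assay, at which 3 of the 3 values shown sit, on the scale. Compound 4 (`O=C(Nc1ccc(F)cc1)c1cc(=O)[nH]c2cc(Br)ccc12`) is not yet measured. It differs from compound 3 by hydrogen in place of fluoro on an aromatic carbon, with hydrogen in place of fluoro on an aromatic carbon, ortho to a large group and meta to a fluoro group.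

For the measured compounds named here, no pair of measured compounds gives a step in this assay, so the expectation rests on limits alone. Compound 3, with > 20000 nM as its limit, offers no number to move from. The expected change is none beyond the scatter, in either direction, and the estimate for a number no higher from compound 3 to compound 4 (the limit leaves the size open) reflects that. A further limit is the likeliest report. For compound 4 the estimated value is 20000 nM, with an expected range of 8000 nM to 30000 nM.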

Compound 4, half-maximal inhibitory concentration: > 20000 nM
Compound 4 gave a limit, no number; the forecaster's own chance of this, stated with the estimate: 75%; the middle value sits exactly at the limit.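

In this assay, no step can be read from compound 3 or compound 2 to compound 4, since each compound carries a limit and not a number: the limit of > 20000 nM in this assay, at which 4 of the 4 values shown sit.

The compounds shown leave open whether these fluoro and chloro changes alter activity at all, and what change to the shared core would give a numerical value.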